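Replacing a benzyl amide with a direct aryl amide

A few compounds are considered here, and "the series" means these few. Any claim that something is new, unique, unknown or untested is made for them only; others in the source may bear on it.

Compound 1 `COc1ccc(CNC(=O)/C=C/c2coc3cc(OC)ccc3c2=O)cc1` carries a 4-methoxybenzyl group on its amide-type nitrogen. In a functional assay on HeLa cells (Homo sapiens) for inhibition, read by MTT assay, with a stated time of 48 h (a lower number here means a stronger inhibitor, a higher number a weaker inhibitor), compound 1 gives only a limit, > 100000 nM. Compound 2 `Cc1ccc(CNC(=O)/C=C/c2coc3cc(O)ccc3c2=O)cc1` bears a 4-methylbenzyl group on the same nitrogen and a hydroxy group on the shared core in place of the methoxy group of compound 1. In this assay compound 2 also returns only the limit of > 100000 nM. Among the compounds with values here, compound 3 `O=C(/C=C/c1coc2cc(O)ccc2c1=O)Nc1ccccc1` is the one compound with a number: with a phenyl on the amide-type nitrogen, compound 3 gives 9700 nM in this assay. Within the data shown here, the single measured step, an at least 10-fold lower number from compound 2 to compound 3 (1.01 log units; beyond the scatter), is thus the only guide to what happens when a benzyl group gives way to a directly attached aryl ring, and its true size is left open at the upper end by the limit of > 100000 nM in this assay, at which 2 of the 3 values shown sit.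

Compound 4 `COc1ccc2c(=O)c(/C=C/C(=O)Nc3ccccc3C)coc2c1` differs from compound 1 at the amide-type nitrogen: 2-methylphenyl in place of 4-methoxybenzyl on an amide-type nitrogen. Among the measured compounds shown here, this is a change of the same kind as the one measured step, a benzyl group giving way to an aryl ring on the amide nitrogen, though here the ring carries a methyl group and the core keeps its methoxy group. Compound 4 is therefore expected to move in the same direction, by an estimated at least 6.6-fold lower number from compound 1 to compound 4 (0.82 log units; beyond the scatter). For compound 4 the estimate in this assay is 15000 nM, within a range from 4000 nM to 70000 nM.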

Compound 4, half-maximal inhibitory concentration: 7270 nM
For compound 4 the middle estimate is 2.1-fold (0.31 log units) above the measured one; measured number inside the range.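

In this assay the change from a benzyl group to an aryl ring on the amide-type nitrogen gives an at least 13-fold lower number from compound 1 to compound 4 (1.13 log units; beyond the scatter) and so appears a second time, now on the core that keeps its methoxy group and with a ring that carries a methyl group. The lower number is therefore seen in two pairs of compounds and is not confined to the hydroxy core or to the plain phenyl ring, though these two pairs are all that support it. As far as these compounds go, the size of the new step stays open at its upper end, since compound 1 stands only at a limit: the limit of > 100000 nM in this assay, at which 2 of the 4 values shown sit.

Compound 3 and compound 4 differ in two places, the methyl group on the ring and the group on the shared core, so the compounds shown do not separate what each of these contributes. Also open, from the compounds shown here alone, is whether the lower number would hold with an amine or a carboxylic acid on the aryl ring, or with a longer chain on the amide-type nitrogen.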